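Aryl replacement at the sulfonamide terminus

The compounds below may be only part of what the source reports. "The series", "measured", "known", "first", "only" and "open" are said of these compounds alone.

Compound 2 `COc1ccc(N2C[C@@H](C)N[C@@H](C)C2)cc1NS(=O)(=O)c1ccc(-c2ccccc2)cc1` gives, in a functional assay for agonist activity at growth hormone secretagogue receptor type 1 (Homo sapiens), read by FLIPR (a lower number here means a smaller maximal response, a higher number a larger maximal response), a maximal response of 1. Compound 1 `COc1ccc(NS(=O)(=O)c2ccc(-c3ccccn3)s2)cc1N1C[C@@H](C)N[C@@H](C)C1` gives 0.9 in this assay; the two values lie within the scatter of each other, so no order between them is claimed. Compound 3 `COc1ccc(N2C[C@@H](C)N[C@@H](C)C2)cc1NS(=O)(=O)c1ccc(-c2ccc(C)o2)cc1` differs from compound 2 by 5-methylfuran-2-yl in place of phenyl on an aromatic carbon. Going by the values given here, no measured pair shows the effect of such an exchange, so the expected step a number 0.050 lower from compound 2 to compound 3 (within the scatter) is taken as none beyond the scatter. Compound 3 is therefore estimated at 0.95, with a range from 0.75 to 1.05.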

Compound 3, intrinsic activity: the largest response reached, as a fraction of the reference agonist's: 1
Estimate against measurement, compound 3: 0.050 below; low and high end bracket the measured number.
By their numbers in this assay, from the lowest: compounds 1, 2 and 3 (each within the scatter of the next).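

In this assay, going by these compounds alone, 5-methylfuran-2-yl in place of phenyl gives no change at the digits printed from compound 2 to compound 3 (within the scatter), the first one-place comparison at this position. The maximal response at this para position thus holds across a change from a six-membered aromatic ring of carbon only to a five-membered aromatic ring with 1 hetero atom. Nothing available explains this outcome. Open, from the compounds shown here alone, is whether an amine, a carboxylic acid or a longer chain in this place would keep the maximal response, and how furan-2-yl without its methyl would compare.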